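Swapping a Dimethylamino Tail for a Piperidine Ring

The compounds below may be only part of what the source reports. "The series", "measured", "known", "first", "only" and "open" are said of these compounds alone.

Three compounds share one core and differ only in the amine-bearing tail attached to the chain. In a physicochemical assay for lipophilicity, using the shake flask method, measured as octanol-water partition, at pH 7.4 (a higher number here means a more lipophilic compound, a lower number a more polar compound), compound 1 `COc1cc(/C=C/C(=O)Nc2ccccc2)ccc1OCCCCN1CCCC1` gives 1.6, compound 2 `COc1cc(/C=C/C(=O)Nc2ccccc2)ccc1OCCCCCCCCN(C)C` gives 1.74, and compound 3 `COc1cc(/C=C/C(=O)Nc2ccccc2)ccc1OCCCCCCCCCCN(C)C` gives 1.8. Compound 3 sits beside the other two, separated by a number 0.06 log units higher from compound 2 to compound 3 (within the scatter) and by a number 0.20 log units higher from compound 1 to compound 3 (within the scatter), both within the scatter. Compound 4 `COc1cc(/C=C/C(=O)Nc2ccccc2)ccc1OCCCCCCCCCCN1CCCCC1` carries the change (piperidin-1-yl in place of dimethylamino on a saturated chain carbon, ten or more bonds along the chain from an oxygen on an aromatic ring). Among the measured compounds shown here, two measured steps bear on this: the step of a number 0.14 log units higher from compound 1 to compound 2 (within the scatter) and the step of a number 0.06 log units higher from compound 2 to compound 3 (within the scatter), each small, so no more than a slight rise is expected here. Compound 4 is therefore expected to give 2, with a range from 1.7 to 2.4. The expected step of a number 0.20 log units higher from compound 3 to compound 4 (within the scatter) would sit close to the edge of the scatter.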

Compound 4, partition coefficient: 1.83
For compound 4 the middle estimate is 0.17 log units above the measured one; the range from low to high includes it.
By their numbers in this assay, from the lowest: compounds 1, 2, 3 and 4 (each within the scatter of the next).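

In this assay, closing the tail amine into piperidin-1-yl in place of dimethylamino, on a saturated chain carbon, gives a number 0.03 log units higher from compound 3 to compound 4 (within the scatter) and so leaves the number effectively unchanged. The wider comparisons, a number 0.09 log units higher from compound 2 to compound 4 (within the scatter) and a number 0.23 log units higher from compound 1 to compound 4 (within the scatter), also stay inside the scatter, so all four tails read alike here. Nothing available offers a reason for this. From the compounds shown here alone, whether a morpholine ring or a carboxylic acid in place of piperidin-1-yl would give a step beyond the scatter remains open.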